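This account rests on a few compounds, and the source may have more. Where it says the series, first, only, none or still open, it means among the compounds named here.

Among the measured compounds shown here, compound 1 `CC(C)[C@H](NC(=O)COc1cccc2ccccc12)C(=O)N[C@@H](CC(=O)O)C(=O)CSc1nc(-c2ccccc2)no1` is one of two compounds measured in a functional assay on Jurkat cells (Homo sapiens) for inhibition (a higher number here means a weaker inhibitor, a lower number a stronger inhibitor), where compound 1 gives 102000 nM. Its companion, compound 2 `Cc1nnc(SCC(=O)[C@H](CC(=O)O)NC(=O)[C@@H](NC(=O)COc2cccc3ccccc23)C(C)C)s1`, carries a 5-methyl-1,3,4-thiadiazol-2-yl in place of the 3-phenyl-1,2,4-oxadiazol-5-yl on the sulfur, and in this assay compound 2 gives 190000 nM. The step of a 1.9-fold higher number from compound 1 to compound 2 (0.27 log units; within the scatter) lies within the scatter, so the two numbers cannot be told apart; compound 1 simply has the lower of the two values.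

Compound 3 `CC(C)[C@H](NC(=O)COc1cccc2ccccc12)C(=O)N[C@@H](CC(=O)O)C(=O)CSc1nc2ccccc2s1` differs from compound 1 at the same sulfur: 1,3-benzothiazol-2-yl in place of 3-phenyl-1,2,4-oxadiazol-5-yl on a sulfur. For the measured compounds named here, the only measured step that bears on this change is a 1.9-fold higher number from compound 1 to compound 2 (0.27 log units; within the scatter), which exchanged the group on that sulfur without a shift beyond the scatter. On that basis the step of a 1.2-fold higher number from compound 1 to compound 3 (0.07 log units; within the scatter) is expected to stay within the scatter as well, with no direction that can be called. Compound 3 is therefore estimated to give 120000 nM in this assay, within a range from 40000 nM to 360000 nM.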

Compound 3, half-maximal inhibitory concentration: > 200000 nM
Compound 3 ended at the assay's limit; the forecaster's own chance of this, stated with the estimate: 15%; middle value at least 1.6-fold (0.22 log units) from the limit.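

Compound 3 sits at a limit of this assay and has no exact value: the limit of > 200000 nM in this assay, at which 1 of the 3 values shown sits. Read against the other two compounds, the result is an at least 1.9-fold higher number from compound 1 to compound 3 (0.29 log units; that floor lies within the scatter) and an at least 1.0-fold higher number from compound 2 to compound 3 (0.02 log units; that floor lies within the scatter), so both steps are floors only. Among the compounds shown here, a third group on this sulfur, 1,3-benzothiazol-2-yl, therefore gives no sign of a stronger inhibitor, and for the first time a step at this position has no upper bound, so its true size could lie beyond the scatter.

Still open, as far as these compounds go, is whether any group on this sulfur can move the number beyond the scatter in the stronger direction. A plain phenyl ring or a short alkyl chain in this place, neither of them among the compounds shown, would help to answer that.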